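A few compounds are considered here, and "the series" means these few. Any claim that something is new, unique, unknown or untested is made for them only; others in the source may bear on it.

Compound 1, `Cc1ccc(S(=O)(=O)N2C/C(=C\c3ccc(F)cc3)C(=O)/C(=C/c3ccc(F)cc3)C2)cc1`, gives 4500 nM in a functional assay on HepG2 cells (Homo sapiens) for cytotoxicity, read by MTT assay, with a stated time of 24 h; on this read-out higher numbers stand for weaker inhibition and lower numbers for stronger inhibition.
Compound 2, `O=C1/C(=C/c2ccc(F)cc2)CN(S(=O)(=O)c2ccc(O[N+](=O)[O-])cc2)C/C1=C\c1ccc(F)cc1`, gives 5400 nM in this assay.
Compound 3, `O=C1/C(=C/c2ccc(F)cc2)CN(S(=O)(=O)c2ccc(Br)cc2)C/C1=C\c1ccc(F)cc1`, gives 8000 nM in this assay.

The three compounds share one core and differ only in the group on the aromatic ring attached to the sulfonyl. The number for compound 3 sits alongside the other two: the steps of a 1.8-fold higher number from compound 1 to compound 3 (0.25 log units; within the scatter) and a 1.5-fold higher number from compound 2 to compound 3 (0.17 log units; within the scatter) both lie within the usual scatter, so no ordering among the three can be read from them.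

Compound 4, `CC(=O)Nc1ccc(S(=O)(=O)N2C/C(=C\c3ccc(F)cc3)C(=O)/C(=C/c3ccc(F)cc3)C2)cc1`, is the next step from compound 3: acetamido in place of bromo on an aromatic carbon. All three measured steps change the same position on that ring, and each stayed within the scatter: a 1.2-fold higher number from compound 1 to compound 2 (0.08 log units; within the scatter), a 1.8-fold higher number from compound 1 to compound 3 (0.25 log units; within the scatter) and a 1.5-fold higher number from compound 2 to compound 3 (0.17 log units; within the scatter). None of them puts an acetamido there, so the expectation rests only on how little this position has mattered so far. In this assay the expected step is a 1.1-fold lower number from compound 3 to compound 4 (0.06 log units; within the scatter), that is, nothing beyond the scatter. Compound 4 is therefore estimated at 7000 nM, within a range from 3000 nM to 18000 nM.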

Compound 4, half-maximal inhibitory concentration: 7400 nM
Estimate against measurement, compound 4: 1.1-fold (0.02 log units) below; the range from low to high includes it.
By their numbers in this assay, from the lowest: compounds 1, 2, 4 and 3 (each within the scatter of the next).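

In this assay, acetamido in place of bromo brings 4 heavy atoms, 1 hydrogen-bond donor and 1 hydrogen-bond acceptor to this aromatic carbon, yet a 1.1-fold lower number from compound 3 to compound 4 (0.03 log units; within the scatter) is a step that stays within the scatter. Against the other two groups, a 1.4-fold higher number from compound 2 to compound 4 (0.14 log units; within the scatter) and a 1.6-fold higher number from compound 1 to compound 4 (0.22 log units; within the scatter) are also within the scatter, so this position has now held four different groups, one of them carrying an amide hydrogen, with no readable order among the four compounds. Nothing measured here says why the numbers stay so close.

As far as these compounds go, it remains open whether an amine, a carboxylic acid or a longer chain at this place would also stay within the scatter. From the compounds shown here alone, it is equally open whether a change elsewhere on the shared core would move the number further, as every step shown sits at this one carbon.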